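A few compounds are considered here, and "the series" means these few. Any claim that something is new, unique, unknown or untested is made for them only; others in the source may bear on it.

Working notes on the series. Compound 1 `Oc1ccc(-c2cc(-c3ccccc3F)cc(-c3cccc(O)c3)n2)cc1` sets the reference: in a functional assay on DU-145 cells (Homo sapiens) for inhibition (on this read-out higher numbers stand for weaker inhibition and lower numbers for stronger inhibition), compound 1 gives 3160 nM. Compound 2 `Oc1ccc(-c2cc(-c3ccccc3F)cc(-c3ccc(O)cc3)n2)cc1` carries the same core; in this assay compound 2 gives 7780 nM. Going by the values given here, the single measured step, a 2.5-fold higher number from compound 1 to compound 2 (0.39 log units; beyond the scatter), concerns the placement of the hydroxyl on one of the outer rings and nothing else. Among the compounds with values here, on the two numbers in hand compound 2 stands highest, with compound 1 as its only and nearest neighbour, lower by that modest step.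

Compound 3 `Oc1ccc(-c2cc(-c3ccccc3C(F)(F)F)cc(-c3ccc(O)cc3)n2)cc1` is the next member to be run in this assay. It differs from compound 2 by trifluoromethyl in place of fluoro on an aromatic carbon. Within the data shown here, no measured pair bears on this change: the one step available, a 2.5-fold higher number from compound 1 to compound 2 (0.39 log units; beyond the scatter), alters a different ring and says nothing about the fluorinated one. Among the measured compounds shown here, with no precedent for this exchange, the default expectation is a step of no clear direction, and the estimated step of a 1.0-fold higher number from compound 2 to compound 3 (0.01 log units; within the scatter) is taken as within the usual scatter. Compound 3 is therefore expected near 8000 nM, with a range from 2500 nM to 25000 nM to cover the open question.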

Compound 3, half-maximal inhibitory concentration: > 50000 nM
Compound 3: a limit, no number; the forecaster's own chance of this, stated with the estimate: 10%; at least 6.2-fold (0.79 log units) between middle value and limit.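

Compound 3 in this assay gives a limit of the assay and not a number: the limit of > 50000 nM in this assay, at which 1 of the 3 values shown sits. Going by these compounds alone, the ring carrying the fluorine, untouched by the only earlier step, now turns out to matter: on this aromatic carbon, ortho to a large group, trifluoromethyl in place of fluoro gives an at least 6.4-fold higher number from compound 2 to compound 3 (0.80 log units; beyond the scatter), and the upper end of that step stays unknown. Compound 1 and compound 2 showed only that moving a hydroxyl on an outer ring shifts the read-out; this pair shows that the substituent at the fluorinated position can also shift it, towards weaker inhibition.

On these data alone, a single exchange fixes one direction at this position and no trend, so it remains open how a methyl, a methoxy or an amine in the same place would read, and whether a group of intermediate size would keep the inhibition seen with fluoro. Also open, as far as these compounds go, is whether trifluoromethyl would act in the same way alongside the 3-hydroxyphenyl ring of compound 1.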